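Tert-butyl on the Phenyl Ring and Cell Toxicity

A few compounds are considered here, and "the series" means these few. Any claim that something is new, unique, unknown or untested is made for them only; others in the source may bear on it.

Measured compounds:
- compound 1 `O=C1NC(O)(CCn2cc(-c3ccccc3)nn2)C(OCc2ccccc2)=C1OCc1ccccc1`: > 100000 nM in an ADME assay on HEK293 cells (Homo sapiens) for cytotoxicity, read by MTT assay, with a stated time of 24 h; on this read-out lower numbers stand for stronger inhibition and higher numbers for weaker inhibition
- compound 2 `CC(C)(C)c1ccc(-c2cn(CCC3(O)NC(=O)C(OCc4ccccc4)=C3OCc3ccccc3)nn2)cc1`: > 100000 nM in this assay
- compound 3 `COC1=C(OC)C(O)(CCn2cc(-c3ccccc3)nn2)NC1=O`: 62000 nM in this assay

For compound 1 the value in this assay is a limit of the assay, not a number. For compound 2 the value is likewise a limit. Among the measured compounds shown here, compound 3 gives the only actual number among the three. The two cores, that of compound 1 and that of compound 3, differ in a way that is not broken down here.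

Compound 2 carries tert-butyl in place of hydrogen on an aromatic carbon relative to compound 1. The step that the two limits leave unreadable from compound 1 to compound 2 cannot be read, because the limit of > 100000 nM in this assay, at which 2 of the 3 values shown sit, holds both ends of that pair.

Compound 4 `COC1=C(OC)C(O)(CCn2cc(-c3ccc(C(C)(C)C)cc3)nn2)NC1=O` is not yet measured. It bears tert-butyl in place of hydrogen on an aromatic carbon relative to compound 3, and the surroundings of the place are the same as in the pair of compound 1 and compound 2, so this is the same change made on the other core. Since the earlier step gives no readable size, the expectation for compound 4 rests on the value of compound 3, 62000 nM. The same change left compound 2 at a limit of the assay.

Compound 4 is expected to give 85000 nM in this assay, with a plausible range from 30000 nM to 250000 nM. The expected step is a 1.4-fold higher number from compound 3 to compound 4 (0.14 log units; within the scatter).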

Compound 4, half-maximal inhibitory concentration: 62000 nM
Beside the measured number, compound 4's estimate is 1.4-fold (0.14 log units) above it; the measured number falls inside the stated range.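

On the second core shown, tert-butyl in place of hydrogen on an aromatic carbon gives, in this assay, no change at the digits printed from compound 3 to compound 4 (within the scatter). The matching step on the first core cannot be read, because both of its compounds sit at a limit of the assay, so neither end of that pair is an actual number: the limit of > 100000 nM in this assay, at which 2 of the 4 values shown sit. This leaves a single readable step for the change, which shows that tert-butyl at this place made no visible difference on one core, but it does not show that the two cores respond alike, as there is no second size to set beside it.

The compounds shown leave open how this assay responds to other groups at the same place on either core, such as an amine, a carboxylic acid or a longer chain. They also leave open what a core bearing one benzyloxy group and one methoxy group would give, which would be a single-place step between the two cores.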